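This account rests on a few compounds, and the source may have more. Where it says the series, first, only, none or still open, it means among the compounds named here.

Three analogues sharing one core have been measured in a functional assay on HEK293 cells for positive allosteric modulation of metabotropic glutamate receptor 5 (Homo sapiens), read by calcium flux; on this read-out lower numbers stand for smaller maximal responses and higher numbers for larger maximal responses. Compound 1 `O=C1c2cc(COc3ccccc3)nn2CCN1c1ccc(F)c(F)c1` gives 81%, compound 2 `COc1ccc(N2CCn3nc(COc4ccccc4)cc3C2=O)cc1` gives 58% and compound 3 `O=C1c2cc(COc3ccccc3)nn2CCN1c1ccncc1` gives 72%. Compound 3 thus sits between the other two: a number 9 percentage points lower from compound 1 to compound 3 (within the scatter), whereas a number 14 percentage points higher from compound 2 to compound 3 (beyond the scatter). Compound 4 `O=C1c2cc(COc3ccccc3)nn2CCN1c1ncc(F)cn1` differs from compound 3 only at the group on the amide-type nitrogen in the ring: 5-fluoropyrimidin-2-yl in place of pyridin-4-yl on an amide-type nitrogen in a ring. The steps bearing on this change are the earlier exchanges at that same nitrogen, a number 23 percentage points lower from compound 1 to compound 2 (beyond the scatter) together with the two steps to compound 3, all modest or within scatter. A small shift in this assay is therefore expected for compound 4, a number 2 percentage points lower from compound 3 to compound 4 (within the scatter), likely within scatter. Compound 4 is estimated at 70%, between 55% and 85%.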

Compound 4, largest response reached (Emax), in percent of the reference or control that the assay uses: 72%
Beside the measured number, compound 4's estimate is 2 percentage points below it; low and high end bracket the measured number.
By their numbers in this assay, from the lowest: compound 2; then compounds 3, 4 and 1 (each within the scatter of the next).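

With 5-fluoropyrimidin-2-yl on the amide-type nitrogen in the ring, a six-membered aromatic ring with 2 hetero atoms reads like one with 1 hetero atom in this assay: no change at the digits printed from compound 3 to compound 4 (within the scatter). Against the two phenyl groups, the new group separates only from 4-methoxyphenyl, with a number 14 percentage points higher from compound 2 to compound 4 (beyond the scatter), and not from 3,4-difluorophenyl, with a number 9 percentage points lower from compound 1 to compound 4 (within the scatter); of the four groups, 4-methoxyphenyl alone stands apart. No evidence at hand accounts for this. Open, as far as these compounds go, is whether a saturated amine such as piperidinyl, or a plain alkyl chain, at this nitrogen keeps the response.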